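The source may hold more compounds than are shown below. What is called first, only, known or untested is meant among the compounds shown, and "the series" means these compounds.

Values in a functional assay on the whole organism (strain Sprague-Dawley) for inhibition, with Rattus norvegicus as the target, with a stated time of 10 min; on this read-out higher numbers stand for an effect only at larger amounts of compound and lower numbers for an effect already at smaller amounts:
- compound 1 `CCOc1ccc(OC)cc1-c1ncc(C(=O)O)c(=O)[nH]1`: 0.2 mg/kg
- compound 2 `CCOc1ccc([N+](=O)[O-])cc1-c1ncc(C(=O)O)c(=O)[nH]1`: 25 mg/kg
- compound 3 `CCOc1ccc(S(=O)(=O)N(CC)CC)cc1-c1ncc(C(=O)O)c(=O)[nH]1`: 40 mg/kg

Compound 2, at 25 mg/kg, holds the second highest of the three numbers. Its nearest neighbour is reached by a 1.6-fold higher number from compound 2 to compound 3 (0.20 log units; within the scatter), and the furthest gap is a 130-fold higher number from compound 1 to compound 2 (2.10 log units; beyond the scatter).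

Compound 4 `CCOC(=O)c1cnc(-c2cc([N+](=O)[O-])ccc2OCC)[nH]c1=O` differs from compound 2 at the carboxy group, which becomes ethoxycarbonyl: ethyl in place of hydrogen on an oxygen next to a carbonyl group. Among the compounds with values here, no measured step touches this place. All three steps exchange the methoxy, nitro or diethylsulfamoyl group, so they show only how widely this series can move, from a 1.6-fold higher number from compound 2 to compound 3 (0.20 log units; within the scatter) up to a 200-fold higher number from compound 1 to compound 3 (2.30 log units; beyond the scatter). They give neither size nor direction for the new change.

The expectation therefore starts from compound 2 at 25 mg/kg, with no step beyond the scatter expected and a wide margin on both sides. The estimated change is a 1.2-fold higher number from compound 2 to compound 4 (0.08 log units; within the scatter). For compound 4 the expected value is 30 mg/kg, within an estimated range of 5 mg/kg to 120 mg/kg.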

Compound 4, dose for 50% inhibition: 5 mg/kg
The estimate for compound 4 lay 6.0-fold (0.78 log units) above the measured number; measured number inside the range.
By their numbers in this assay, from the lowest: compound 1; then compound 4; then compounds 2 and 3 (each within the scatter of the next).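

In this assay the carboxy position proves open to change: ethyl in place of hydrogen on an oxygen next to a carbonyl group gives a 5.0-fold lower number from compound 2 to compound 4 (0.70 log units; beyond the scatter) and so moves the number in the direction of smaller amounts. With the nitro group in place, a free carboxy group is therefore not needed for an effect in the whole animal, and the ethoxycarbonyl compound 4 gives a lower number than the acid. No measurement at hand accounts for this step.

The compounds shown leave open whether the same step holds with methoxy or diethylsulfamoyl in place of nitro, so the result is tied to the nitro compounds alone. They also leave open how methoxycarbonyl, a longer-chain ester such as butoxycarbonyl, or a primary carboxamide would read at this position.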